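Anilinopropanoic acids: phenoxy in place of trifluoromethyl

This account rests on a few compounds, and the source may have more. Where it says the series, first, only, none or still open, it means among the compounds named here.

Three compounds of the series have numbers in a functional assay on CHO cells for agonist activity at Free fatty acid receptor 1 (Homo sapiens), read by reporter gene assay; a lower number here means a smaller maximal response, a higher number a larger maximal response. Compound 1 `O=C(O)C1CC1c1ccc(NCc2ccc(-c3ccccc3)cc2)cc1` gives 80%, compound 2 `O=C(O)CCc1ccc(NCc2ccc(C(F)(F)F)cc2)cc1` gives 133% and compound 3 `O=C(O)CCc1ccc(NCc2ncc[nH]2)cc1` gives 4%. Compound 2 stands highest of the three; compound 1 lies nearest, lower by a margin beyond the scatter, and compound 3 lies furthest, also beyond the scatter. Compound 4 `O=C(O)CCc1ccc(NCc2ccc(Oc3ccccc3)cc2)cc1` is the next member; relative to compound 2 the change is phenoxy in place of trifluoromethyl on an aromatic carbon. Among the measured compounds shown here, no step between two measured compounds isolates this exchange, and compound 1 differs from compound 2 in more than one place. Compound 1, whose group likewise holds a six-membered aromatic ring of carbon only, gives 80%, which suggests a moderate decrease. A downward step of moderate size is expected, a number 28 percentage points lower from compound 2 to compound 4 (beyond the scatter). Compound 4 is therefore estimated at 105%, within a range from 70% to 140%.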

Compound 4, largest response reached (reported as percent of maximum), in percent of the reference or control that the assay uses: 139%
The estimate for compound 4 lay 34 percentage points below the measured number; the measured number falls inside the stated range.
By their numbers in this assay, from the lowest: compound 3; then compound 1; then compounds 2 and 4 (each within the scatter of the next).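

Among the compounds shown here, this is the first step that isolates the exchange at this position: on an aromatic carbon para to a large group, phenoxy in place of trifluoromethyl gives a number 6 percentage points higher from compound 2 to compound 4 (within the scatter) in this assay. The maximal response therefore holds with 7 heavy atoms and a six-membered aromatic ring in the entering group, against 4 heavy atoms and no ring in the leaving one. Nothing on hand bears on why the response holds.

Open, on these data alone, is whether a methoxy or benzyloxy group at this position would also hold the response. Also open, as far as these compounds go, is whether a basic group such as an amine would be tolerated there.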